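Bromophenyl placement on the triazole across two cores

This account rests on a few compounds, and the source may have more. Where it says the series, first, only, none or still open, it means among the compounds named here.

Compound 1 `N#CC1=C(N)Oc2c(c3nc4ccccc4nc3c3ccccc23)C12C(=O)N(Cc1cnnn1-c1ccccc1Br)c1ccccc12` and compound 2 `N#CC1=C(N)Oc2c(c3nc4ccccc4nc3c3ccccc23)C12C(=O)N(Cc1cnnn1-c1cccc(Br)c1)c1ccccc12` share one core, while compound 3 `N#CC1=C(N)Oc2c(N)cc3nc4ccccc4nc3c2C12C(=O)N(Cc1cnnn1-c1cccc(Br)c1)c1ccccc12` carries a second core; the difference between the two cores is not broken down here. In an ADME assay on HUVEC cells (Homo sapiens) for antiproliferative activity, read by MTT assay, with a stated time of 48 h (a lower number here means a stronger inhibitor, a higher number a weaker inhibitor), compound 1 gives > 50000 nM, which is a limit of the assay and not a number. In this assay compound 2 gives > 50000 nM, again a limit. In this assay compound 3 gives > 50000 nM, also a limit. Compound 2 and compound 1 differ in 2-bromophenyl in place of 3-bromophenyl on an aromatic nitrogen and the step that the two limits leave unreadable from compound 2 to compound 1 cannot be sized because of the limit of > 50000 nM in this assay, at which 3 of the 3 values shown sit. Compound 4 `N#CC1=C(N)Oc2c(N)cc3nc4ccccc4nc3c2C12C(=O)N(Cc1cnnn1-c1ccccc1Br)c1ccccc12` has not been measured; it differs from compound 3 in 2-bromophenyl in place of 3-bromophenyl on an aromatic nitrogen, the same change at the same place as the one made between the other two compounds of the first core. For compound 4 the step that the limit leaves unreadable from compound 3 to compound 4 is expected to be about flat. That expectation rests on the limit of > 50000 nM in this assay, at which 3 of the 3 values shown sit, together with a step that the two limits leave unreadable from compound 2 to compound 1, which leave the direction of this change unknown but give no sign of a gain. Compound 4 is accordingly estimated at 70000 nM in this assay, most likely reported as a limit.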

Compound 4, half-maximal inhibitory concentration: 34200 nM
Compound 4: the middle estimate sits 2.0-fold (0.31 log units) above what was measured; measured number inside the range.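

In this assay, on the core of compound 3, 2-bromophenyl in place of 3-bromophenyl on an aromatic nitrogen gives an at least 1.4-fold lower number from compound 3 to compound 4 (0.16 log units; that floor lies within the scatter). Within the data shown here, since that floor lies within the scatter, the step shows only that compound 4 gives a measured number rather than a limit; it does not establish a real gain of any particular size. The same change on the core of compound 1 cannot be read, so nothing here shows that the change carries from one core to the other, and the two steps cannot be compared because both compounds of the first pair sit at the limit: the limit of > 50000 nM in this assay, at which 3 of the 4 values shown sit.

As far as these compounds go, it remains open how far the values behind the limits lie and whether the measured number of compound 4 belongs to this core alone. Also open, from the compounds shown here alone, is how a 2-aminophenyl or 2-carboxyphenyl group would read in place of 2-bromophenyl on either core.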